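The compounds below may be only part of what the source reports. "The series", "measured", "known", "first", "only" and "open" are said of these compounds alone.

Measured in a functional assay on G-361 cells (Homo sapiens) for antiproliferative activity, with a stated time of 72 h; on this read-out higher numbers stand for weaker inhibition and lower numbers for stronger inhibition:
- compound 1 `OC[C@H]1O[C@@H](n2cnc3c(NCc4ccccc4Br)ncnc32)[C@H](O)[C@@H]1O`: > 166000 nM (a limit)
- compound 2 `OC[C@H]1O[C@@H](n2cnc3c(NCc4ccc(Cl)cc4Cl)ncnc32)[C@H](O)[C@@H]1O`: 128000 nM
- compound 3 `OC[C@H]1O[C@@H](n2cnc3c(NCc4ccc(Cl)c(Cl)c4)ncnc32)[C@H](O)[C@@H]1O`: 145000 nM

Among the compounds with values here, compound 3 gives 145000 nM, and the only other exact number lies close to it: a 1.1-fold higher number from compound 2 to compound 3 (0.05 log units; within the scatter). Compound 1 is reported only as a limit: the limit of > 166000 nM in this assay, at which 1 of the 3 values shown sits. The two steps that start from that limit, an at least 1.2-fold lower number from compound 1 to compound 2 (0.11 log units; that floor lies within the scatter) and an at least 1.1-fold lower number from compound 1 to compound 3 (0.05 log units; that floor lies within the scatter), have floors within the scatter, so they show no real separation.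

Compound 4 `OC[C@H]1O[C@@H](n2cnc3c(NCc4ccc(F)cc4F)ncnc32)[C@H](O)[C@@H]1O` keeps the shared core but carries 2,4-difluorophenyl in place of 3,4-dichlorophenyl, on a saturated chain carbon bound to a nitrogen on an aromatic ring: 2,4-difluorophenyl in place of 3,4-dichlorophenyl on a saturated chain carbon bound to a nitrogen on an aromatic ring. Within the data shown here, no measured step swaps chlorine for fluorine, so the three steps above are only indirect guides. Among the measured compounds shown here, with a 1.1-fold higher number from compound 2 to compound 3 (0.05 log units; within the scatter) as the one exact step, no change beyond the scatter is expected in this assay. The expected step is a 1.0-fold higher number from compound 3 to compound 4 (0.01 log units; within the scatter). For compound 4 the estimated value is 150000 nM, with an expected range from 80000 nM to 250000 nM.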

Compound 4, half-maximal inhibitory concentration: > 166000 nM
Compound 4: no number, only a limit; the forecaster's own chance of this, stated with the estimate: 35%; middle value at least 1.1-fold (0.04 log units) away from the limit.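

In this assay compound 4 is reported only as a limit, > 166000 nM. The two readable steps, an at least 1.1-fold higher number from compound 3 to compound 4 (0.05 log units; that floor lies within the scatter) and an at least 1.2-fold higher number from compound 2 to compound 4 (0.11 log units; that floor lies within the scatter), have floors within the scatter, so 2,4-difluorophenyl shows no real separation from either dichlorophenyl group, and the step that joins the two limits cannot be read. Fluorine thus joins chlorine and bromine on this ring without opening a readable gap, and compound 1 and compound 4 now share one limit: the limit of > 166000 nM in this assay, at which 2 of the 4 values shown sit.

From the compounds shown here alone, whether any group at this position can bring the number clearly down remains open. A phenyl ring carrying a methoxy group, an amine or a carboxylic acid, or a longer chain between the ring and the nitrogen, would extend the comparison beyond halogens alone.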